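This account rests on a few compounds, and the source may have more. Where it says the series, first, only, none or still open, it means among the compounds named here.

Series notes. Compound 1 `Cc1c(C(=O)Nc2ccc(Oc3ccnc4[nH]ccc34)c(F)c2)nnn1-c1ccc(F)cc1` carries a 4-fluorophenyl group on the five-membered aromatic ring of the shared core; in a functional assay on MCF7 cells (Homo sapiens) for cytotoxicity, read by MTT assay, with a stated time of 72 h (on this read-out lower numbers stand for stronger inhibition and higher numbers for weaker inhibition), compound 1 gives 170 nM. Compound 2 `COc1ccc(-n2nnc(C(=O)Nc3ccc(Oc4ccnc5[nH]ccc45)c(F)c3)c2C)cc1` carries a 4-methoxyphenyl group at the same position, and in this assay compound 2 stands at "not determined" (no result reported), so no single number places it against compound 1. Compound 3 `Cc1c(C(=O)Nc2ccc(Oc3ccnc4[nH]ccc34)c(F)c2)nnn1-c1ccc(F)c(F)c1` differs from compound 2 by 3,4-difluorophenyl in place of 4-methoxyphenyl on an aromatic nitrogen. Going by the values given here, no measured step runs between compound 2 and compound 3 in this assay, so the size of this step cannot be read from the data; compound 1, the only compound with a number, gives the nearest point of reference. Within the scatter of this assay, compound 3 is expected to land close to compound 1, at an estimated 200 nM, with a plausible range from 60 nM to 700 nM.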

Compound 3, half-maximal inhibitory concentration: 820 nM
Compound 3: the middle estimate sits 4.1-fold (0.61 log units) below what was measured, and the stated range ends below it.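

In this assay the aryl group on the aromatic nitrogen of the five-membered ring responds to a single added fluoro: 3,4-difluorophenyl in place of 4-fluorophenyl gives a 4.8-fold higher number from compound 1 to compound 3 (0.68 log units; beyond the scatter) and so weaker inhibition. Going by these compounds alone, this is the first readable step, and it shows that fluoro in place of hydrogen on an aromatic carbon of this phenyl ring is enough to move the read-out beyond the usual scatter. Nothing at hand accounts for the shift.

Steps that involve compound 2 cannot be read, so 4-methoxyphenyl stays unplaced against both fluorinated groups. Also open, as far as these compounds go, is where an unsubstituted phenyl, or a phenyl carrying an amine or a carboxylic acid, would fall relative to compound 1 and compound 3.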